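From compound 2 to compound 4 in the same cell assay

The source may hold more compounds than are shown below. What is called first, only, known or untested is meant among the compounds shown, and "the series" means these compounds.

The measured compounds:
compound 1, `CC(C)=CCC/C(C)=C/COc1cc(=O)n(CCCO)c2c1CC(C/C=C(\C)CCC=C(C)C)C(C)(C)C2`, in a functional assay on PANC-1 cells (Homo sapiens) for inhibition, read by MTT assay, with a stated time of 24 h, tested at 10 uM (on this read-out lower numbers stand for less inhibition and higher numbers for more inhibition at the one concentration tested (going by the name of the read-out)), compound 1 gives 15.8%;
compound 2, `CC(C)=CCC/C(C)=C/CC1Cc2c(OCCCNS(=O)(=O)c3ccc(Br)cc3)cc(=O)n(CCCO)c2CC1(C)C`, in this assay compound 2 gives 15.2%;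
compound 3, `CC(C)=CCC/C(C)=C/CC1Cc2c(OCCCNS(=O)(=O)c3ccc([N+](=O)[O-])cc3)cc(=O)n(CCCO)c2CC1(C)C`, in this assay compound 3 gives 7.4%.

All three share one core and differ only in the arm attached through the oxygen on the aromatic ring. Compound 2 stands with compound 1 and compound 3 on either side of it, and its gap to each of them is within the scatter, so the three numbers cannot be told apart. Within the data shown here, the one single-point step on record, nitro in place of bromo on an aromatic carbon, runs a number 7.8 percentage points lower from compound 2 to compound 3 (within the scatter).

Compound 4, `COc1ccc(OCCCOc2cc(=O)n(CCCO)c3c2CC(C/C=C(\C)CCC=C(C)C)C(C)(C)C3)cc1`, differs from compound 2 by 4-methoxyphenoxy in place of ((4-bromophenyl)sulfonyl)amino on a saturated chain carbon, three bonds along the chain from an oxygen on an aromatic ring. Among the measured compounds shown here, no measured step touches this part of the arm, and the only step that exists shows no movement beyond the scatter. The change from compound 2 to compound 4 is therefore expected to give a step of a number 0.2 percentage points lower from compound 2 to compound 4 (within the scatter) in this assay, meaning none beyond the scatter. For compound 4 the expected result is 15%, with a range from 4% to 28%.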

Compound 4, a percentage reported as inhibition, at one concentration (the size of the read-out at that concentration, not a potency): 20%
The estimate for compound 4 lay 5 percentage points below the measured number, within the range that was stated.
By their numbers in this assay, from the lowest: compounds 3, 2, 1 and 4 (each within the scatter of the next, the first and the last beyond it).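

In this assay the arm attached through the oxygen on the aromatic ring also accepts an ether end: 4-methoxyphenoxy in place of ((4-bromophenyl)sulfonyl)amino runs a number 4.8 percentage points higher from compound 2 to compound 4 (within the scatter). The second change at this arm, 2-(4-methoxyphenoxy)ethyl in place of 2,6-dimethylhepta-1,5-dien-1-yl on a saturated chain carbon bound to an oxygen on an aromatic ring, runs a number 4.2 percentage points higher from compound 1 to compound 4 (within the scatter), so neither exchange of the arm's end moves the read-out beyond the scatter. No outside evidence bears on these numbers.

From the compounds shown here alone, whether an amine or a carboxylic acid in place of 4-methoxyphenoxy, or a longer chain in the arm, would move the read-out beyond the scatter remains open. So does the effect of any change to the shared core, which all four compounds keep.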